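The source may report more compounds than this note shows. Statements on the series, on what has been measured and on what is new or still open speak of the compounds shown alone.

Measured in a physicochemical assay for solubility; on this read-out higher numbers stand for higher solubility and lower numbers for lower solubility:
Compound 1 `CCCCCCCCCCCCCCCC(=O)n1c(=S)oc2ccccc21`: 63000 nM
Compound 2 `CCCCCCCCCC(=O)n1c(=S)oc2ccccc21`: 100000 nM
Compound 3 `CCCCCC(=O)n1c(=S)n(C(C)=O)c2ccccc21`: 49000 nM

Compound 2 has the highest of the three numbers, with compound 1 within the scatter of it and compound 3 beyond the scatter. The next compound, compound 4 `CCCCCC(=O)n1c(=S)oc2ccccc21`, differs from compound 2 by hydrogen in place of butyl on a saturated chain carbon, five bonds along the chain from a carbonyl carbon. For the measured compounds named here, one measured step bears on this change, a similar replacement of hexyl by hydrogen, which gave a 1.6-fold higher number from compound 1 to compound 2 (0.20 log units; within the scatter). A step of similar direction, not beyond the scatter, is therefore expected, and the estimated step is a 1.1-fold higher number from compound 2 to compound 4 (0.04 log units; within the scatter). For compound 4 the expected value is 110000 nM, with an estimated range of 60000 nM to 190000 nM.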

Compound 4, solubility: 130000 nM
Beside the measured number, compound 4's estimate is 1.2-fold (0.07 log units) below it, within the range that was stated.
By their numbers in this assay, from the lowest: compounds 3, 1, 2 and 4 (each within the scatter of the next, the first and the last beyond it).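

In this assay, hydrogen in place of butyl on this saturated chain carbon, five bonds along the chain from a carbonyl carbon, gives a 1.3-fold higher number from compound 2 to compound 4 (0.11 log units; within the scatter) and so, like a 1.6-fold higher number from compound 1 to compound 2 (0.20 log units; within the scatter) on the same core, stays within the scatter. A second removal of chain carbons therefore brings no step beyond the scatter on this core. Nothing available explains this result.

The compounds shown leave open whether an amine or a carboxylic acid at this chain position would give a step beyond the scatter. They also leave open whether the same change behaves alike on the core of compound 3.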